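A few compounds are considered here, and "the series" means these few. Any claim that something is new, unique, unknown or untested is made for them only; others in the source may bear on it.

Measured in a functional assay on HT-29 cells (Homo sapiens) for antiproliferative activity, read by MTT assay, with a stated time of 72 h; on this read-out lower numbers stand for stronger inhibition and higher numbers for weaker inhibition:

- Compound 1 `COC(=O)/C=C/CNc1ccc(Cl)c(S(=O)(=O)N(C)C)c1`: > 30000 nM (a limit, not a number)
- Compound 2 `C=CC(=O)Nc1nc(-c2ccccc2O)cs1`: 16200 nM
- Compound 3 `C=CC(=O)N(Cc1ccccc1)c1nc(-c2ccccc2)cs1`: > 30000 nM (a limit, not a number)

Compound 3 stands at the limit of > 30000 nM in this assay, at which 2 of the 3 values shown sit. Its result is therefore a limit, and it gives no exact potency to start from. Compound 2 is the only one of the three with a numerical result.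

The next compound to be tested is compound 4 `C=CC(=O)N(CC(=O)OC(C)(C)C)c1nc(-c2ccccc2)cs1`. It differs from compound 3 in one place: tert-butoxycarbonyl in place of phenyl on a saturated chain carbon bound to an amide-type nitrogen. Put simply, tert-butoxycarbonyl stands in place of phenyl on a saturated chain carbon bound to an amide-type nitrogen. The same difference, cut one bond further out, reads as benzyl to (tert-butoxycarbonyl)methyl.

No measured pair among these compounds shows what a change of this kind does in this assay. The expectation therefore leans on (the limit of > 30000 nM in this assay, at which 2 of the 3 values shown sit), and no shift in either direction beyond the usual scatter is expected. The estimated size of the change, an at least 1.0-fold lower number from compound 3 to compound 4 (0.02 log units; that floor lies within the scatter), is small and has no firm direction. Another result reported only as a limit would be unsurprising. For compound 4, the estimated value is 28000 nM, with an expected range from 9000 nM to 60000 nM.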

Compound 4, half-maximal inhibitory concentration: > 30000 nM
Compound 4 was reported as a limit (the forecaster's own chance of this, stated with the estimate: 55%); middle value at least 1.0-fold (0.02 log units) from the limit.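

Compound 3 and compound 4 are both reported only as limits in this assay, so the step between them cannot be read, and neither result gives an exact potency: the limit of > 30000 nM in this assay, at which 3 of the 4 values shown sit.

Whether tert-butoxycarbonyl in place of phenyl on a saturated chain carbon bound to an amide-type nitrogen changes the activity at all, in either direction, remains open with the compounds shown.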